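A few compounds are considered here, and "the series" means these few. Any claim that something is new, unique, unknown or untested is made for them only; others in the source may bear on it.

Measured compounds:
compound 1, `C=C1C(=O)OC(C)CC1c1ccc(Br)cc1`: 4510 nM
compound 2, `C=C1C(=O)OC(C)CC1c1ccccc1OC`: 6260 nM
compound 3, `C=C1C(=O)O[C@@H](C)[C@@H]1c1ccc(Br)cc1`: 1100 nM

In a functional assay on NALM-6 cells (Homo sapiens) for cytotoxicity, read by MTT assay, with a stated time of 48 h (on this read-out higher numbers stand for weaker inhibition and lower numbers for stronger inhibition), compound 3 gives 1100 nM, the lowest of the three numbers shown. Compound 1 gives 4510 nM in this assay, a higher number than that of compound 3 by a gap that lies beyond the scatter. Compound 2 gives 6260 nM in this assay, the highest of the three, also beyond the scatter from compound 3. No pair among these three differs in a single place, so no step between measured compounds can be computed.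

Compound 4, `C=C1C(=O)O[C@@H](C)[C@@H]1c1ccc(OC)cc1`, has not yet been measured in this assay. It differs from compound 3 in one place: methoxy in place of bromo on an aromatic carbon. Among the measured compounds shown here, there is no measured pair showing the effect of methoxy in place of bromo on this core, so the expectation rests on the number of compound 3 alone and is uncertain in direction. A modest step toward a weaker number is expected, a 1.8-fold higher number from compound 3 to compound 4 (0.26 log units; within the scatter), though a result within the scatter would not be surprising. Compound 4 is therefore estimated at 2000 nM, with a range from 700 nM to 6000 nM.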

Compound 4, half-maximal inhibitory concentration: 5420 nM
For compound 4 the middle estimate is 2.7-fold (0.43 log units) below the measured one; the measured number falls inside the stated range.
By their numbers in this assay, from the lowest: compound 3; then compounds 1, 4 and 2 (each within the scatter of the next).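

In this assay, the change of methoxy in place of bromo on an aromatic carbon, para to a group of 8 heavy atoms, gives a 4.9-fold higher number from compound 3 to compound 4 (0.69 log units; beyond the scatter) and lies beyond the scatter. Among the compounds shown here, this is the first single-place comparison in the set, and it shows that the number on this core depends on what this aromatic carbon carries, with bromo giving the lower number of the two groups. Nothing measured here accounts for the step.

On these data alone, it remains open how other groups at this place, such as chloro, an amine or a carboxylic acid, would compare with bromo and methoxy. A single step also cannot tell whether the same exchange would shift the number to a similar extent on the core of compound 1.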